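Cyano for Hydroxy: Expected Cytotoxicity of Compound 3

The source may report more compounds than this note shows. Statements on the series, on what has been measured and on what is new or still open speak of the compounds shown alone.

compound 1 `CCc1ccc2[nH]c(=O)c(CN(Cc3cccc(F)c3)Cc3ccc4ccccc4c3)cc2c1`: > 5000 nM
compound 2 `Cc1ccc2[nH]c(=O)c(CN(Cc3ccc(O)cc3)Cc3ccc(C(C)(C)C)cc3)cc2c1`: 4900 nM

Among the measured compounds shown here, in a toxicity assay on MDCK cells (Canis lupus familiaris) for cytotoxicity, read by crystal violet staining, with a stated time of 48 h (on this read-out lower numbers stand for higher toxicity in this test and higher numbers for lower toxicity in this test), compound 2 gives 4900 nM, the only actual number in this set. For compound 1 this assay reports only a limit, > 5000 nM, so compound 2 stands at the limit of > 5000 nM in this assay, at which 1 of the 2 values shown sits, alongside it. Compound 3 `Cc1ccc2[nH]c(=O)c(CN(Cc3ccc(C#N)cc3)Cc3ccc(C(C)(C)C)cc3)cc2c1` differs from compound 2 by cyano in place of hydroxy on an aromatic carbon. For the measured compounds named here, no step between measured compounds is available, so a change in this assay for compound 3 beyond the scatter is not expected; the step of a 1.0-fold higher number from compound 2 to compound 3 (0.01 log units; within the scatter) is estimated as flat. Compound 3 is therefore expected at 5000 nM, between 2500 nM and 10000 nM.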

Compound 3, half-maximal cytotoxic concentration: > 5000 nM
Compound 3: a limit, no number (the forecaster's own chance of this, stated with the estimate: 50%); the middle value lies on the limit itself.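

In this assay, compound 3 gives only a limit, not a number, so the change reads as an at least 1.0-fold higher number from compound 2 to compound 3 (0.00 log units; that floor lies within the scatter). With cyano in place of hydroxy on this aromatic carbon, para to a large group, the hydrogen-bond donor of hydroxy is gone, yet the read-out shows no sign of higher toxicity in this test. The set now rests largely on a single limit: the limit of > 5000 nM in this assay, at which 2 of the 3 values shown sit.

Going by these compounds, the true size of this step stays open, since only its floor can be read. Also open, on these data alone, is how an amine or a carboxylic acid at this place would read out.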